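Benzoyloxy in Place of (tert-Butyl)carbonyloxy: Expected Inhibition

A few compounds are considered here, and "the series" means these few. Any claim that something is new, unique, unknown or untested is made for them only; others in the source may bear on it.

Compound 1 `COc1ccc(C(=O)Nc2ccccc2Cl)cc1OC1CCCC1`: 190 nM in an assay on isolated protein for inhibition of phosphodiesterase 4A (Sus scrofa); on this read-out lower numbers stand for stronger inhibition and higher numbers for weaker inhibition
Compound 2 `COc1ccc(C(=O)Nc2ccccc2Cl)cc1OC(=O)C(C)(C)C`: > 1000000 nM, a limit

Compound 2 stands at the limit of > 1000000 nM in this assay, at which 1 of the 2 values shown sits, so only a bound is known for it. Compound 3 `COc1ccc(C(=O)Nc2ccccc2Cl)cc1OC(=O)c1ccccc1` arises by phenyl in place of tert-butyl on a carbonyl carbon. Among the compounds with values here, the one measured step, an at least 5200-fold higher number from compound 1 to compound 2 (3.72 log units; beyond the scatter), bears on the new compound only indirectly, as compound 3 keeps the carbonyl on the aromatic oxygen. In this assay the expected step is a number no higher from compound 2 to compound 3 (the limit leaves the size open), none beyond the scatter. Compound 3 is therefore expected to give about 1000000 nM, between 200000 nM and 5000000 nM, most likely again reported only as a limit.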

Compound 3, half-maximal inhibitory concentration: > 1000000 nM
Compound 3 ended at the assay's limit; the forecaster's own chance of this, stated with the estimate: 70%; the middle value sits exactly at the limit.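

Replacing cyclopentyl with benzoyl on an oxygen on an aromatic ring gives, in this assay, an at least 5200-fold higher number from compound 1 to compound 3 (3.72 log units; beyond the scatter), so the large rise seen with (tert-butyl)carbonyl is not confined to that one group. The step from compound 2 to compound 3 cannot be read, since both values are limits: the limit of > 1000000 nM in this assay, at which 2 of the 3 values shown sit.

The compounds shown leave open how far compound 2 and compound 3 lie past that limit. They also leave open whether a carbamate or a longer alkyl chain on this oxygen would keep the inhibition of compound 1.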